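Working notes: compound 3 to compound 4

The source may hold more compounds than are shown below. What is called first, only, known or untested is meant among the compounds shown, and "the series" means these compounds.

Measured in an ADME assay on microsomes from liver (Rattus norvegicus) for metabolic stability, using NADPH, with a stated time of 10 min; on this read-out higher numbers stand for a more stable compound and lower numbers for a less stable compound:
- compound 1 `NC/C=C/CN(C[C@H]1Cc2ncccc2CN1)[C@H]1CCCc2cccnc21`: 11%
- compound 2 `NC(=O)NC/C=C/CN(C[C@H]1Cc2ncccc2CN1)[C@H]1CCCc2cccnc21`: 1%
- compound 3 `CN(CCCCN(C[C@H]1Cc2ncccc2CN1)[C@H]1CCCc2cccnc21)C1CCC(F)(F)CC1`: 8%

Compound 3 stands at 8% and lies within the scatter of both compound 1 and compound 2. Compound 4 `CN(CCCCN(C[C@H]1Cc2ncccc2CN1)[C@H]1CCCc2cccnc21)C1CCOCC1` has not yet been measured. It carries oxan-4-yl in place of 4,4-difluorocyclohexyl on an amine nitrogen.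

For the measured compounds named here, no measured step makes this exchange, so the evidence is indirect. Going by the values given here, the only measured step in one place is a different change, carbamoyl in place of hydrogen on an amine nitrogen, and it gives a number 10 percentage points lower from compound 1 to compound 2 (within the scatter) without leaving the scatter. All three measured values lie within the scatter of one another, and nothing shown points to a direction for the new change.

The expected change in this assay is therefore none beyond the scatter, with a number 1 percentage points higher from compound 3 to compound 4 (within the scatter) as the estimated step. For compound 4 the estimated value is 9% (expected range 2% to 22%).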

Compound 4, percent of the compound remaining: 64%
Compound 4: middle estimate off by 55 percentage points, on the low side; the measured number lies above the stated range.
By their numbers in this assay, from the lowest: compounds 2, 3 and 1 (each within the scatter of the next); then compound 4.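

In this assay, for the compounds shown here, oxan-4-yl in place of 4,4-difluorocyclohexyl on this amine nitrogen gives a number 56 percentage points higher from compound 3 to compound 4 (beyond the scatter) and is the first single exchange to leave the scatter, so the group at this place can decide the read-out. The wider replacements on the saturated chain carbon bound to an amine nitrogen give a number 63 percentage points higher from compound 2 to compound 4 (beyond the scatter) and a number 53 percentage points higher from compound 1 to compound 4 (beyond the scatter) and set compound 4 apart from the other three compounds, which lie within the scatter of one another. The data at hand offer no measurement that explains this step.

On these data alone, it remains open whether the step follows from the ring oxygen entering or the two fluorines leaving, and an unsubstituted cyclohexyl at the same place would separate the two. As far as these compounds go, whether the same exchange holds with a piperidin-4-yl or on a shorter chain also remains open.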